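The source may hold more compounds than are shown below. What is called first, only, known or untested is meant among the compounds shown, and "the series" means these compounds.

Measured so far in a functional assay on thoracic aorta (Rattus norvegicus, strain Wistar), with a stated time of 15 min; a lower number here means that less compound is needed, a higher number that more compound is needed for the effect:
- compound 1 `CC(NC(=O)NS(=O)(=O)c1ccc(Cl)cc1)c1cc(Br)ccc1OCc1ccccc1`: 57500 nM
- compound 2 `CC(NC(=O)NS(=O)(=O)c1ccccc1)c1cc(Br)ccc1OCc1ccccc1`: 130000 nM

Of these two, compound 2 carries the higher number, 130000 nM, so more of it is needed for the effect than of compound 1. The next compound, compound 3 `Cc1ccc(S(=O)(=O)NC(=O)NC(C)c2cc(Br)ccc2OCc2ccccc2)cc1`, has methyl in place of hydrogen on an aromatic carbon, para to a large group, which turns the phenyl of compound 2 into 4-methylphenyl: methyl in place of hydrogen on an aromatic carbon.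

Within the data shown here, only one measured step bears on this change, the replacement of chloro by hydrogen on an aromatic carbon: a 2.3-fold higher number from compound 1 to compound 2 (0.35 log units; beyond the scatter). Among the measured compounds shown here, that step is modest, and it shows the compound with the added group as the one with the lower number. Methyl is not chloro, however, and no measured compound carries methyl, so this single step is only a loose guide. In this assay, a small shift toward a lower number is therefore expected, possibly no larger than the scatter. The expected change is a 1.5-fold lower number from compound 2 to compound 3 (0.18 log units; within the scatter). For compound 3 the estimated value is 85000 nM, with an expected range of 40000 nM to 170000 nM.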

Compound 3, half-maximal effective concentration: 138000 nM
For compound 3 the middle estimate is 1.6-fold (0.21 log units) below the measured one; low and high end bracket the measured number.
By their numbers in this assay, from the lowest: compound 1; then compounds 2 and 3 (each within the scatter of the next).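

In this assay, putting methyl on this aromatic carbon, para to a large group, leaves the number where it was (a 1.1-fold higher number from compound 2 to compound 3 (0.03 log units; within the scatter)), so compound 3 cannot be told apart from compound 2, and the added group as such does not carry the step seen earlier. The same position read from chloro to methyl gives a clear step (a 2.4-fold higher number from compound 1 to compound 3 (0.38 log units; beyond the scatter)), so among the three groups seen here only the chloro of compound 1 stands apart, while hydrogen and methyl sit together within the scatter. Nothing at hand explains why chloro differs here from methyl and hydrogen.

What the compounds leave open is whether that separation belongs to chloro alone or would extend to other groups at this position, such as fluoro, methoxy, an amine or a carboxylic acid. As far as these compounds go, all three compounds also share the rest of their structure, so it remains open whether these same replacements would give similar steps on a different core or with a longer chain at the same place.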